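Compound 4: hydroxy replaced by methyl on the branched group

The compounds below may be only part of what the source reports. "The series", "measured", "known", "first", "only" and "open" are said of these compounds alone.

Compound 3 `CC(C)(CO)/N=c1\c(O)c(O)\c1=N/Cc1ccc(C#N)cc1` gives 21300 nM in a functional assay for inhibition, with Rattus norvegicus as the target (on this read-out lower numbers stand for stronger inhibition and higher numbers for weaker inhibition), the highest number among the three measured compounds. Compound 2 `CC(C)C/N=c1\c(O)c(O)\c1=N/Cc1ccc(C#N)cc1` gives 10200 nM and compound 1 `CCC(CC)/N=c1\c(O)c(O)\c1=N/Cc1ccc(C#N)cc1` gives 1300 nM. The change from compound 3 to compound 4 `CCC(C)(C)/N=c1\c(O)c(O)\c1=N/Cc1ccc(C#N)cc1` is methyl in place of hydroxy on a saturated chain carbon, two bonds along the chain from a double-bonded nitrogen. Within the data shown here, two measured steps bear on it, both ending at compound 3: a 16-fold higher number from compound 1 to compound 3 (1.21 log units; beyond the scatter) and a 2.1-fold higher number from compound 2 to compound 3 (0.32 log units; beyond the scatter). In each, the group on the double-bonded nitrogen lacking hydroxy gives the lower number, and the larger step belongs to pentan-3-yl. Compound 4 carries 1,1-dimethylpropyl, so a lower number is expected, though the branching differs from compound 1 and a full return to its level is not assumed. The expected step is an 8.5-fold lower number from compound 3 to compound 4 (0.93 log units; beyond the scatter). Compound 4 is estimated at 2500 nM, with a range from 800 nM to 8000 nM.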

Compound 4, half-maximal inhibitory concentration: 1100 nM
Estimate against measurement, compound 4: 2.3-fold (0.36 log units) above; measured number inside the range.
By their numbers in this assay, from the lowest: compounds 4 and 1 (each within the scatter of the next); then compound 2; then compound 3.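

In this assay, among these compounds, methyl in place of hydroxy gives a 19-fold lower number from compound 3 to compound 4 (1.29 log units; beyond the scatter) and so isolates this one change on a single carbon, which the earlier steps, each swapping the whole group on a double-bonded nitrogen, could not do. Branching alone does not set the number here: 1,1-dimethylpropyl in place of isobutyl gives a 9.3-fold lower number from compound 2 to compound 4 (0.97 log units; beyond the scatter) and in place of pentan-3-yl gives a 1.2-fold lower number from compound 1 to compound 4 (0.07 log units; within the scatter) within the scatter. No measurement shown gives a reason for these steps.

Open, going by these compounds, is whether an amine, a methoxy or a carboxylic acid on that carbon would track methyl or hydroxy. Also open, on these data alone, is whether a longer chain would move the number from the level shared by compound 4 and compound 1.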